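The compounds below may be only part of what the source reports. "The series", "measured", "known", "first", "only" and "open" are said of these compounds alone.

Measured so far in an assay on HeLa cells for binding affinity to Vasopressin V2 receptor (Homo sapiens); a lower number here means a stronger inhibitor, a higher number a weaker inhibitor:

compound 1 `Cc1cc(N)ccc1C(=O)N1CCCCc2cc(Cl)ccc21`: 4.1 nM
compound 2 `CCN(CC)c1ccc(C(=O)N2CCCCc3ccccc32)c(Cl)c1`: 19 nM
compound 3 `CN(C)c1ccc(C(=O)N2CCCCc3cc(Cl)ccc32)c(Cl)c1`: 13 nM

Compound 2 gives the highest number of the three in this assay. Compound 3 lies close to it, within the scatter of repeated measurements, so the two cannot be ordered against each other. Compound 1 lies beyond the scatter, with a clearly lower number than compound 2.

The next compound, compound 4 `O=C(c1ccc(N2CCCCC2)cc1Cl)N1CCCCc2ccccc21`, differs from compound 2 in one place: piperidin-1-yl in place of diethylamino on an aromatic carbon. The two nitrogen substituents are joined into a ring; nothing else in the molecule is touched. Among the compounds with values here, no pair among the measured compounds shows this kind of change, so there is no directly comparable step in this assay to draw on. The expectation is a small step, no larger than the usual scatter, with no clear direction: an expected step of a 1.3-fold lower number from compound 2 to compound 4 (0.10 log units; within the scatter).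

Compound 4 is therefore estimated at 15 nM in this assay, with a likely range from 5 nM to 45 nM.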

Compound 4, half-maximal inhibitory concentration: 120 nM
Beside the measured number, compound 4's estimate is 8.0-fold (0.90 log units) below it; the measured number lies above the stated range.
By their numbers in this assay, from the lowest: compound 1; then compounds 3 and 2 (each within the scatter of the next); then compound 4.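

Joining the two nitrogen substituents into a ring is not a neutral change at this position in this assay: piperidin-1-yl in place of diethylamino gives a 6.3-fold higher number from compound 2 to compound 4 (0.80 log units; beyond the scatter) on the only step available. The change adds one heavy atom and a six-membered non-aromatic ring, while the hydrogen-bond donor and acceptor counts and the absence of net charge stay the same, so these counts do not separate the two compounds. No measurement on these two groups bears on the reason for this step.

From the compounds shown here alone, it remains open whether the higher number goes with the ring itself or with the added carbon; pyrrolidin-1-yl and morpholin-4-yl on the same aromatic carbon would help separate these. Because the step rests on a single pair, its transfer to the chlorinated core of compound 3 is also unknown.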